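Two Aryl Ethers Measured, a Third Awaiting Its Number

The source may report more compounds than this note shows. Statements on the series, on what has been measured and on what is new or still open speak of the compounds shown alone.

Compound 1, `COc1cccc(OC)c1OCCNCCOc1ccccc1OCc1ccc(Cl)cc1`, gives 9.11 in a functional assay on thoracic aorta for antagonist activity at Alpha-1D adrenergic receptor (Rattus norvegicus); a lower number here means a less potent compound, a higher number a more potent compound, by a factor of ten per unit of this negative logarithm.
Compound 2, `COc1ccccc1COc1ccccc1OCCNCCOc1c(OC)cccc1OC`, gives 8.86 in this assay.

Compound 2 has a single measured neighbour, and the step of a number 0.25 log units lower from compound 1 to compound 2 (within the scatter) is within the scatter, so the two numbers cannot be told apart. Compound 3, `COc1cccc(OC)c1OCCNCCOc1ccccc1OCc1ccc(OC(C)C)cc1`, is reached from compound 2 by one change: 4-isopropoxyphenyl in place of 2-methoxyphenyl on a saturated chain carbon bound to an oxygen on an aromatic ring. Among the measured compounds shown here, the only measured step, a number 0.25 log units lower from compound 1 to compound 2 (within the scatter), also exchanges the aryl group at this same place and left the number essentially where it was. No measurement exists for a 4-isopropoxyphenyl group at this position, so the expectation rests on that one step alone. The step from compound 2 to compound 3 is therefore expected to be about a number 0.14 log units higher from compound 2 to compound 3 (within the scatter), none beyond the scatter. Compound 3 is estimated at 9 in this assay, with a range from 8.4 to 9.6.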

Compound 3, negative logarithm of the antagonist equilibrium constant: 9.14
The estimate for compound 3 lay 0.14 log units below the measured number; low and high end bracket the measured number.
By their numbers in this assay, from the lowest: compounds 2, 1 and 3 (each within the scatter of the next).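

With 4-isopropoxyphenyl in this place, this assay records a number 0.28 log units higher from compound 2 to compound 3 (within the scatter) and, for isopropoxy in place of chloro on an aromatic carbon, a number 0.03 log units higher from compound 1 to compound 3 (within the scatter); neither step can be told apart from the scatter of repeated measurements. The position on a saturated chain carbon bound to an oxygen on an aromatic ring has now carried three different substituted phenyl groups, including one of 10 heavy atoms and one of 8, with no difference these numbers can resolve. Nothing measured here speaks to a reason for this.

As far as these compounds go, all three compounds carry a phenyl group at this position, so it remains open whether a cyclohexyl group or a plain butyl chain would keep the number in the same range. Also open, from the compounds shown here alone, is what an amine or a carboxylic acid on that phenyl ring would do.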